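This account rests on a few compounds, and the source may have more. Where it says the series, first, only, none or still open, it means among the compounds named here.

Compound 1 `CCOC(=O)/C(=C/c1ccccc1)CN1C(=O)[C@@H](OC)[C@H]1c1ccc(Cl)cc1` in a functional assay on MDA-MB-231 cells (Homo sapiens) for antiproliferative activity, read by MTT assay, with a stated time of 48 h (on this read-out higher numbers stand for weaker inhibition and lower numbers for stronger inhibition), gives 11100 nM
Compound 2 `COC(=O)/C(=C/c1ccccc1)CN1C(=O)[C@@H](OC)[C@H]1c1cccc(C(F)(F)F)c1` gives 18200 nM
Compound 3 `COC(=O)/C(=C/c1ccccc1)CN1C(=O)[C@@H](OC)[C@H]1c1cccc(F)c1` gives 34400 nM

Compound 1 has the lowest number of the three, though only its gap to compound 3 lies beyond the scatter; its gap to compound 2 does not. Going by the values given here, the single measured step, a 1.9-fold higher number from compound 2 to compound 3 (0.28 log units; within the scatter), swaps one group for another on the aromatic ring and does not touch the change now in question. Compound 4 `CCOC(=O)/C(=C/c1ccccc1)CN1C(=O)[C@@H](OC)[C@H]1c1ccccc1Br` differs from compound 1 as follows: 2-bromophenyl in place of 4-chlorophenyl on a saturated ring carbon. Among the compounds with values here, no measured step covers an exchange of one halogenated phenyl for another, so no shift beyond the scatter is expected. The estimated step is a 1.1-fold higher number from compound 1 to compound 4 (0.03 log units; within the scatter), and compound 4 is expected to give 12000 nM, within a range from 4000 nM to 36000 nM.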

Compound 4, half-maximal inhibitory concentration: 6860 nM
Beside the measured number, compound 4's estimate is 1.7-fold (0.24 log units) above it, and the stated range covers the measured number.
By their numbers in this assay, from the lowest: compounds 4, 1, 2 and 3 (each within the scatter of the next, the first and the last beyond it).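

On the saturated ring carbon of the four-membered ring, 2-bromophenyl in place of 4-chlorophenyl gives a 1.6-fold lower number from compound 1 to compound 4 (0.21 log units; within the scatter) in this assay. This position therefore tolerates a change in both the halogen and its place on the phenyl ring, with no shift beyond the scatter. No measurement available here offers an explanation for this result.

Because the halogen and its place change together, their separate contributions cannot be told apart; a 2-chlorophenyl group would address this. On these data alone, how a phenyl ring carrying an amine or a carboxylic acid would behave at this carbon also remains open.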